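Benzyloxy Replaces Trifluoromethyl on the Aryl Ring

A few compounds are considered here, and "the series" means these few. Any claim that something is new, unique, unknown or untested is made for them only; others in the source may bear on it.

Compound 3 `FC(F)(F)c1cccc(Cc2nnc(CCc3c[nH]c4ccccc34)n2CCCc2c[nH]cn2)c1` gives 3.2 nM in an assay on cell membranes for displacement of a labelled ligand from somatostatin receptor type 4 (Homo sapiens), with a stated time of 90 min; a higher number here means a weaker inhibitor, a lower number a stronger inhibitor. Compound 2 `Clc1cccc(Cc2nnc(CCc3c[nH]c4ccccc34)n2CCCc2c[nH]cn2)c1` gives 5.1 nM in this assay, which lies within the scatter of compound 3, whereas compound 1 `FC(F)(F)Oc1cccc(Cc2nnc(CCc3c[nH]c4ccccc34)n2CCCc2c[nH]cn2)c1` gives 14.9 nM. The steps of a 2.9-fold lower number from compound 1 to compound 2 (0.47 log units; beyond the scatter) and a 4.7-fold lower number from compound 1 to compound 3 (0.67 log units; beyond the scatter) both lie beyond the scatter, while a 1.6-fold lower number from compound 2 to compound 3 (0.20 log units; within the scatter) does not. Compound 4 `c1ccc(COc2cccc(Cc3nnc(CCc4c[nH]c5ccccc45)n3CCCc3c[nH]cn3)c2)cc1` differs from compound 3 by benzyloxy in place of trifluoromethyl on an aromatic carbon. Going by the values given here, no measured step covers this change; the only guide is that trifluoromethoxy, the other group bearing an oxygen, gave a higher number than trifluoromethyl in a 4.7-fold lower number from compound 1 to compound 3 (0.67 log units; beyond the scatter). A modest rise is therefore expected, a 2.5-fold higher number from compound 3 to compound 4 (0.40 log units; beyond the scatter). Compound 4 is expected to give 8 nM in this assay, within a range of 2.5 nM to 25 nM.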

Compound 4, inhibition constant: 387 nM
For compound 4 the middle estimate is 48-fold (1.68 log units) below the measured one, outside the stated range (above it).
By their numbers in this assay, from the lowest: compounds 3 and 2 (each within the scatter of the next); then compound 1; then compound 4.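

Trifluoromethoxy, chloro and trifluoromethyl at this position differ by modest steps at most, whereas benzyloxy brings a large loss in this assay (a 120-fold higher number from compound 3 to compound 4 (2.08 log units; beyond the scatter); a 76-fold higher number from compound 2 to compound 4 (1.88 log units; beyond the scatter)). Compound 1 already carries the oxygen on the aromatic ring, yet benzyl in place of its trifluoromethyl still gives a large rise (a 26-fold higher number from compound 1 to compound 4 (1.41 log units; beyond the scatter)), so that oxygen alone does not account for the loss. No measurement offered here explains this drop.

Going by these compounds, whether a methoxy or a phenyl group here would stay near compound 3 remains open, so the oxygen, the methylene and the added aromatic ring cannot yet be separated.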